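Cytotoxicity notes: a dimethylphenyl variant of compound 1

The source may report more compounds than this note shows. Statements on the series, on what has been measured and on what is new or still open speak of the compounds shown alone.

Measured so far in a functional assay on C8166 cells (Homo sapiens) for cytotoxicity, read by MTT assay; on this read-out higher numbers stand for lower toxicity in this test and lower numbers for higher toxicity in this test:
compound 1, `Cc1cc(S(N)(=O)=O)ccc1NC(=O)COc1ccc(Cl)cc1NC(=O)c1ccccc1`: 207000 nM
compound 2, `Cc1cc(S(N)(=O)=O)ccc1NC(=O)COc1ccc(Cl)cc1NC(=O)c1ccccc1C`: 67300 nM
compound 3, `Cc1cc(S(N)(=O)=O)ccc1NC(=O)COc1ccc(Cl)cc1NC(=O)c1cccc(C(F)(F)F)c1`: 124000 nM

Compound 1 holds the highest of the three numbers in this assay; the nearest is compound 3, reached by a 1.7-fold lower number from compound 1 to compound 3 (0.22 log units; within the scatter), and the furthest is compound 2, reached by a 3.1-fold lower number from compound 1 to compound 2 (0.49 log units; beyond the scatter).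

Compound 4, `Cc1ccc(C)c(C(=O)Nc2cc(Cl)ccc2OCC(=O)Nc2ccc(S(N)(=O)=O)cc2C)c1`, is not yet measured. It differs from compound 1 as follows: 2,5-dimethylphenyl in place of phenyl on a carbonyl carbon. The step that bears on this change is the methyl step, a 3.1-fold lower number from compound 1 to compound 2 (0.49 log units; beyond the scatter), which lies beyond the scatter, whereas the trifluoromethyl step, a 1.7-fold lower number from compound 1 to compound 3 (0.22 log units; within the scatter), stayed within it. A step of similar size and direction is expected for compound 4, because compound 2 showed a 3.1-fold lower number from compound 1 to compound 2 (0.49 log units; beyond the scatter); the expected step is a 3.5-fold lower number from compound 1 to compound 4 (0.54 log units; beyond the scatter). The estimate for compound 4 is 60000 nM, with a range of 20000 nM to 160000 nM.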

Compound 4, half-maximal cytotoxic concentration: 79700 nM
Beside the measured number, compound 4's estimate is 1.3-fold (0.12 log units) below it; the range from low to high includes it.
By their numbers in this assay, from the lowest: compounds 2, 4, 3 and 1 (each within the scatter of the next, the first and the last beyond it).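

In this assay series, this assay, 2,5-dimethylphenyl on the carbonyl carbon gives a step from phenyl that lies beyond the scatter (a 2.6-fold lower number from compound 1 to compound 4 (0.41 log units; beyond the scatter)). The second methyl does not separate the result from the 2-methylphenyl of compound 2 (a 1.2-fold higher number from compound 2 to compound 4 (0.07 log units; within the scatter)), and 3-(trifluoromethyl)phenyl is not separated from 2,5-dimethylphenyl either (a 1.6-fold lower number from compound 3 to compound 4 (0.19 log units; within the scatter)). Nothing available explains these steps. Still open, as far as these compounds go, is whether a single methyl in the 5-position of the ring alone gives such a step. Also open, from the compounds shown here alone, is how an amine or a carboxylic acid on this ring would read.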